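The compounds below may be only part of what the source reports. "The series", "measured", "known", "first", "only" and "open" are said of these compounds alone.

Measured compounds in a physicochemical assay for solubility, read by HPLC, in phosphate buffer, measured as thermodynamic solubility, with a stated time of 24 h, at pH 6.8; a lower number here means a less soluble compound, a higher number a more soluble compound:
Compound 1, `CCc1cnc(N2CCC(n3ncc4cc(-c5ccc(S(C)(=O)=O)cc5)ncc43)CC2)nc1`: compound 1 gives 260 nM.
Compound 2, `CCNC(=O)c1ccc(-c2cc3nnn(C4CCN(c5ncc(CC)cn5)CC4)c3cn2)cc1C`: compound 2 gives 1790 nM.
Compound 3, `CCNC(=O)c1ccc(-c2cc3nnn(C4CCN(c5ncc(CC)cn5)CC4)c3cn2)cc1Cl`: compound 3 gives < 160 nM, which is a limit of the assay and not a number.

Compound 3 thus stands at the bottom of the three values shown; it sits at the limit of < 160 nM in this assay, at which 1 of the 3 values shown sits. Compound 1 lies between compound 2 and the limit of compound 3, with no single-point relation to either. For the measured compounds named here, the one measured step in this assay is an at least 11-fold lower number from compound 2 to compound 3 (1.04 log units; beyond the scatter), a large drop that carried compound 3 out of the measurable range.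

Compound 4, `CCNC(=O)c1ccc(-c2cc3nnn(C4CCN(c5ncc(CC)cn5)CC4)c3cn2)cc1C(F)(F)F`, differs from compound 3 by trifluoromethyl in place of chloro on an aromatic carbon. Going by the values given here, no measured pair covers a chloro-to-trifluoromethyl exchange, so the step from compound 2 to compound 3 bears on it only as the single precedent at this position, and it gives no sign of a recovery in solubility. Compound 4 is therefore expected to remain at or under the limit, with a step that the limit leaves unreadable from compound 3 to compound 4 as the estimated step. The estimate for compound 4 is 100 nM, between 40 nM and 320 nM, most likely again reported only as a limit.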

Compound 4, solubility: 510 nM
Compound 4: the middle estimate sits 5.1-fold (0.71 log units) below what was measured; the whole stated range lies below it.
By their numbers in this assay, from the lowest: compounds 1 and 4 (each within the scatter of the next); then compound 2. At a limit, below all of these: compound 3.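

In this assay, the aromatic carbon ortho to the ethylcarbamoyl group does not simply lose with every replacement of methyl: trifluoromethyl in place of chloro gives an at least 3.1-fold higher number from compound 3 to compound 4 (0.50 log units; beyond the scatter), which brings the series back to a measured number. Methyl still holds the highest number at this position, since trifluoromethyl in its place gives a 3.5-fold lower number from compound 2 to compound 4 (0.55 log units; beyond the scatter), a smaller loss than the one seen with chloro in an at least 11-fold lower number from compound 2 to compound 3 (1.04 log units; beyond the scatter). Compound 3 is known only by a limit, so the gain from chloro to trifluoromethyl has a lower bound and no upper one: the limit of < 160 nM in this assay, at which 1 of the 4 values shown sits.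

From the compounds shown here alone, whether an amine or a methoxy group at this position would stay near methyl or fall toward chloro remains open. Also open, going by these compounds, is whether the same order of methyl, trifluoromethyl and chloro holds on the core of compound 1.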